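The compounds below may be only part of what the source reports. "The series", "measured", "known", "first", "only" and "open" are said of these compounds alone.

Measured so far in an assay for binding affinity, read by spectrophotometry; on this read-out higher numbers stand for weaker inhibition and lower numbers for stronger inhibition: compound 1 `C[C@H](CCCN1CCCC1)Nc1ccnc2cc(Cl)ccc12` gives 140000 nM; compound 2 `C[C@H](CCCN1CCCCC1)Nc1ccnc2cc(Cl)ccc12` gives 130000 nM; compound 3 `C[C@@H](CCCN1CCCCC1)Nc1ccnc2cc(Cl)ccc12` gives 150000 nM.

Compound 2 stands beside the other two on these numbers: the step of a 1.1-fold lower number from compound 1 to compound 2 (0.03 log units; within the scatter) and the step of a 1.2-fold higher number from compound 2 to compound 3 (0.06 log units; within the scatter) both sit within the scatter, the latter pair differing only in configuration as drawn (the fact that compounds 2 and 3 differ only in the configuration as drawn). Compound 4 `C[C@H](CCCNC(C)(C)C)Nc1ccnc2cc(Cl)ccc12` is not yet measured; it carries (tert-butyl)amino in place of piperidin-1-yl on a saturated chain carbon, four bonds along the chain from a nitrogen on an aromatic ring. Among the compounds with values here, the only measured step that bears on the basic amine, the exchange of pyrrolidin-1-yl for piperidin-1-yl, moved this assay by nothing beyond the scatter, so no step beyond the scatter is expected here either: a 1.1-fold higher number from compound 2 to compound 4 (0.03 log units; within the scatter). Compound 4 is therefore estimated at 140000 nM, with a range from 70000 nM to 280000 nM.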

Compound 4, half-maximal inhibitory concentration: 170000 nM
Estimate against measurement, compound 4: 1.2-fold (0.08 log units) below, within the range that was stated.
By their numbers in this assay, from the lowest: compounds 2, 1, 3 and 4 (each within the scatter of the next).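

In this assay, exchanging a ring amine for the open-chain (tert-butyl)amino, which brings a hydrogen-bond donor, stays within the scatter: a 1.3-fold higher number from compound 2 to compound 4 (0.12 log units; within the scatter), and a 1.2-fold higher number from compound 1 to compound 4 (0.08 log units; within the scatter). At this place, on a saturated chain carbon, four bonds along the chain from a nitrogen on an aromatic ring, neither the ring nor that donor separates these compounds. Nothing available bears on why this exchange leaves the number within the scatter.

From the compounds shown here alone, whether a primary amine, a carboxylic acid or a longer chain at this place would give a step beyond the scatter remains open.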